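Adding bromo to compound 3: working notes

A few compounds are considered here, and "the series" means these few. Any claim that something is new, unique, unknown or untested is made for them only; others in the source may bear on it.

Values in a functional assay on KB cells (Homo sapiens) for cytotoxicity, read by MTT assay, with a stated time of 72 h; a lower number here means a stronger inhibitor, a higher number a weaker inhibitor:
- compound 1 `O=S(=O)(c1ccccc1)c1nc2ccccc2nc1N1CCCC1`: 35800 nM
- compound 2 `O=S(=O)(c1ccc(Br)cc1)c1nc2ccccc2nc1N1CCc2ccccc2C1`: > 50000 nM, a limit of the assay
- compound 3 `O=S(=O)(c1ccccc1)c1nc2ccccc2nc1N1CCCC(O)C1`: 3590 nM

Within the data shown here, of the two values that are true numbers, the lower belongs to compound 3, and the only measured step is a 10-fold lower number from compound 1 to compound 3 (1.00 log units; beyond the scatter). That step, 3-hydroxypiperidin-1-yl in place of pyrrolidin-1-yl, lies elsewhere on the molecule and gives no size for the next change.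

Compound 4 `O=S(=O)(c1ccc(Br)cc1)c1nc2ccccc2nc1N1CCCC(O)C1` has bromo in place of hydrogen on an aromatic carbon, para to a large group: bromo in place of hydrogen on an aromatic carbon.

Compound 2 also carries 4-bromophenyl, and its > 50000 nM is a limit. Among the measured compounds shown here, no measured step isolates bromo, so only a small move toward a higher number is expected in this assay, possibly within the scatter.

The estimated change is a 1.4-fold higher number from compound 3 to compound 4 (0.14 log units; within the scatter). For compound 4 the expected value is 5000 nM, with an estimated range of 1300 nM to 22000 nM.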

Compound 4, half-maximal inhibitory concentration: 3720 nM
Beside the measured number, compound 4's estimate is 1.3-fold (0.13 log units) above it, and the stated range covers the measured number.
By their numbers in this assay, from the lowest: compounds 3 and 4 (each within the scatter of the next); then compound 1. At a limit, above all of these: compound 2.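

In this assay, 4-bromophenyl in place of phenyl gives a 1.0-fold higher number from compound 3 to compound 4 (0.02 log units; within the scatter), so with 3-hydroxypiperidin-1-yl present, this position para to a large group accepts bromo without a change beyond the scatter. On these data alone, with 4-bromophenyl held constant, 3-hydroxypiperidin-1-yl in place of 1,2,3,4-tetrahydroisoquinolin-2-yl gives an at least 13-fold lower number from compound 2 to compound 4 (1.12 log units; beyond the scatter), and the true size of this step stays open. The value of compound 2 is a limit: the limit of > 50000 nM in this assay, at which 1 of the 4 values shown sits.

Still open, as far as these compounds go, is whether bromo behaves the same way alongside the pyrrolidin-1-yl group of compound 1. Also open, from the compounds shown here alone, is how a methoxy group, an amine or a carboxylic acid would fare at this position.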